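A few compounds are considered here, and "the series" means these few. Any claim that something is new, unique, unknown or untested is made for them only; others in the source may bear on it.

Compound 1 `CC1(C)Cc2c(OCc3ccccc3)ccc(C(=O)/C=C/c3ccc(F)cc3)c2O1` carries a fluoro group on its outer aromatic ring, and in a functional assay on NCI-H460 cells (Homo sapiens) for antiproliferative activity, read by MTT assay, with a stated time of 48 h (on this read-out higher numbers stand for weaker inhibition and lower numbers for stronger inhibition), compound 1 gives 22300 nM. Among the compounds with values here, compound 2 `COc1ccc(/C=C/C(=O)c2ccc(OCc3ccccc3)c3c2OC(C)(C)C3)cc1` differs from it by the single change (methoxy in place of fluoro on an aromatic carbon). In this assay compound 2 reaches only the upper limit of the measurement, > 100000 nM, so that its number is a limit rather than a measured concentration. The resulting step is an at least 4.4-fold higher number from compound 1 to compound 2 (0.65 log units; beyond the scatter), a reading that rests on (the limit of > 100000 nM in this assay, at which 1 of the 3 values shown sits).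

Compound 3 `CC1(C)Cc2c(ccc(C(=O)/C=C/c3ccc(F)cc3)c2OCc2ccccc2)O1` has the same atoms as compound 1, joined differently; the difference between the two cores is not broken down here. In this assay compound 3 gives 75800 nM, which is the higher of the two numbers that are not limits.

Compound 4 `COc1ccc(/C=C/C(=O)c2ccc3c(c2OCc2ccccc2)CC(C)(C)O3)cc1` is not yet measured. It stands to compound 3 exactly as compound 2 stands to compound 1, through the same change (methoxy in place of fluoro on an aromatic carbon). Since compound 3 already starts from the higher number 75800 nM, and since the same change on compound 1 produced an at least 4.4-fold higher number from compound 1 to compound 2 (0.65 log units; beyond the scatter), the account expects compound 4 to move by a 4.0-fold higher number from compound 3 to compound 4 (0.60 log units; beyond the scatter). On that basis compound 4 is estimated to give about 300000 nM in this assay, most probably reported only as a limit, with an expected span from 90000 nM to 1000000 nM.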

Compound 4, half-maximal inhibitory concentration: > 100000 nM
Compound 4 was reported as a limit; the forecaster's own chance of this, stated with the estimate: 80%; the middle value is on the limit's open side.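

In this assay compound 4 is reported only as a limit, > 100000 nM, and it is the second compound in the series to stand there: the limit of > 100000 nM in this assay, at which 2 of the 4 values shown sit.

On the second core, the change of methoxy in place of fluoro therefore reads as an at least 1.3-fold higher number from compound 3 to compound 4 (0.12 log units; that floor lies within the scatter). This agrees in direction with the step on the core of compound 1, but its floor alone does not establish a shift beyond the scatter on this core. The data thus show that the change has not restored activity on either core, but they do not show that it carries over with the same size, and the two steps cannot be set against each other as numbers: the same change on two cores in this assay, an at least 4.4-fold higher number (0.65 log units; beyond the scatter) from compound 1 to compound 2 and an at least 1.3-fold higher number (0.12 log units; that floor lies within the scatter) from compound 3 to compound 4; the limit leaves it open whether they differ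

From the compounds shown here alone, what remains open is how far compound 2 and compound 4 actually lie past the limit, and so whether the core alters the size of the change at all. The compounds shown also leave open what an amine, a carboxylic acid or a longer chain such as ethoxy would do in place of fluoro or methoxy on the outer aromatic ring in this assay.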